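Swapping a Triazolyl Ring for an Acetamido Group

The source may report more compounds than this note shows. Statements on the series, on what has been measured and on what is new or still open speak of the compounds shown alone.

Measured compounds:
compound 1 `CCCCCCSc1nnc(COc2ccc(-n3cnnc3)cc2)o1` — 28.4 mg/kg
compound 2 `O=C1CCc2cc(OCc3nnc(SCc4ccc(C(F)(F)F)cc4)o3)ccc2N1` — 27.6 mg/kg
compound 3 `CCCCCSc1nnc(COc2ccc3c(c2)CCC(=O)N3)o1` — 10.2 mg/kg

All three were tested in a functional assay on the whole organism (strain Kunming) with Mus musculus as the target, with a stated time of 30 min; a higher number here means that more compound is needed for the effect, a lower number that less compound is needed. Compound 1 has the highest of the numbers shown, but its gap to compound 2 lies within the usual scatter, so these two cannot be told apart; compound 3 sits clearly lower than compound 1.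

Compound 4 `CCCCCCSc1nnc(COc2ccc(NC(C)=O)cc2)o1` has not yet been measured. It differs from compound 1 in one place: acetamido in place of 4H-1,2,4-triazol-4-yl on an aromatic carbon. The shared core is untouched.

Going by the values given here, only one step between measured compounds is available, a 2.7-fold lower number from compound 2 to compound 3 (0.43 log units; beyond the scatter), and it concerns the chain bound to the sulfur, not the ring where compound 4 is altered. Among the compounds with values here, no measured pair shows what happens when the 4H-1,2,4-triazol-4-yl group gives way to acetamido, so nothing in these data points in a direction for this assay. Without such a reference, the expectation is that compound 4 stays close to compound 1, with an expected step of a 1.1-fold lower number from compound 1 to compound 4 (0.04 log units; within the scatter) that does not exceed the scatter. Compound 4 is therefore estimated at 26 mg/kg, with a plausible range from 12 mg/kg to 55 mg/kg.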

Compound 4, dose for half-maximal effect: 26.8 mg/kg
Compound 4: middle estimate off by 1.0-fold (0.01 log units), on the low side, within the range that was stated.
By their numbers in this assay, from the lowest: compound 3; then compounds 4, 2 and 1 (each within the scatter of the next).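

In this assay, going by these compounds alone, putting acetamido in place of 4H-1,2,4-triazol-4-yl on this aromatic carbon, para to a large group, gives the first measured exchange at this position (a 1.1-fold lower number from compound 1 to compound 4 (0.03 log units; within the scatter)), and the two compounds cannot be told apart. The two groups differ clearly on paper: the one that leaves is a five-membered aromatic ring with 0 hydrogen-bond donors and 3 hydrogen-bond acceptors, while the one that enters has no ring, 1 hydrogen-bond donor and 1 hydrogen-bond acceptor. In this one pair, then, the position tolerates that difference in ring and in those counts without a change that the read-out can separate from the scatter, and no data are available that explain why.

Going by these compounds, two groups at one position cannot show how far this tolerance reaches, so it remains open whether a plain amine or a carboxylic acid on the same aromatic carbon would also leave the number in place. On these data alone, it also remains open how a longer chain on the sulfur would act when combined with the acetamido group of compound 4.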